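A tert-butyl swap among compounds held at the limit

This account rests on a few compounds, and the source may have more. Where it says the series, first, only, none or still open, it means among the compounds named here.

Within the data shown here, in an ADME assay on MCF7 cells (Homo sapiens) for inhibition (on this read-out lower numbers stand for stronger inhibition and higher numbers for weaker inhibition), no measured compound has yet given a number. Compound 1 `COC(=O)c1cc2c(F)c(F)c(Sc3ccc(C(C)(C)C)cc3)c(F)c2s1` reads > 50000 nM as a limit. Compound 2 `O=C(c1ccccc1)c1cc2c(F)c(F)c(Oc3ccccc3Br)c(F)c2s1` reads > 25000 nM as a limit. Compound 3 `O=C(c1ccccc1)c1cc2c(F)c(F)c(Sc3ccccc3Br)c(F)c2s1` reads > 25000 nM as a limit, and so it stands at the limit of > 25000 nM in this assay, at which 2 of the 3 values shown sit, rather than on a measured value.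

Among the measured compounds shown here, compound 4 `CC(C)(C)c1ccc(Sc2c(F)c(F)c3cc(C(=O)c4ccccc4)sc3c2F)cc1` carries 4-(tert-butyl)phenyl in place of 2-bromophenyl on a sulfur as its only change from compound 3.

For the measured compounds named here, the one measured step is a step that the two limits leave unreadable from compound 2 to compound 3 and it changes the atom carrying the 2-bromophenyl group, so it gives no size to borrow. Compound 1 also carries 4-(tert-butyl)phenyl on a sulfur, and it too stops at a limit, the limit of > 50000 nM in this assay, at which 1 of the 3 values shown sits, in this case.

No step beyond the scatter is therefore expected, and no direction can be assigned. The expected change is a step that the limit leaves unreadable from compound 3 to compound 4 on this estimate. Compound 4 is estimated at 30000 nM in this assay, with an expected range of 10000 nM to 60000 nM for its value.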

Compound 4, half-maximal inhibitory concentration: > 25000 nM
Compound 4 was reported as a limit; the forecaster's own chance of this, stated with the estimate: 75%; the middle value is on the limit's open side.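

In this assay compound 4 gives > 25000 nM, which is a limit and not a number. Neither step to it, from compound 3 or from compound 1, can be read. The compounds shown leave open whether 4-(tert-butyl)phenyl in place of 2-bromophenyl on a sulfur changes the read-out at all.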